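Carbonyl aryl swaps: from compound 3 to compound 4

This account rests on a few compounds, and the source may have more. Where it says the series, first, only, none or still open, it means among the compounds named here.

Values in a functional assay on B16-F10 cells (Mus musculus) for antiproliferative activity, read by MTT assay, with a stated time of 48 h; on this read-out higher numbers stand for weaker inhibition and lower numbers for stronger inhibition:
- compound 1 `COc1ccc(/C=C/c2cc(OC)cc(OC)c2/C=C/C(=O)c2cccc(Br)c2)cc1`: 5.1 ug/mL
- compound 2 `COc1ccc(/C=C/c2cc(OC)cc(OC)c2/C=C/C(=O)c2cccc(Cl)c2)cc1`: 3.3 ug/mL
- compound 3 `COc1ccc(/C=C/c2cc(OC)cc(OC)c2/C=C/C(=O)c2ccccc2C)cc1`: 6.1 ug/mL

Compound 3 gives 6.1 ug/mL and is not separated from the other two compounds, with a 1.2-fold higher number from compound 1 to compound 3 (0.08 log units; within the scatter) and a 1.8-fold higher number from compound 2 to compound 3 (0.27 log units; within the scatter). The next compound, compound 4 `COc1ccc(/C=C/c2cc(OC)cc(OC)c2/C=C/C(=O)c2ccc(OC)cc2)cc1`, keeps the shared core and has 4-methoxyphenyl in place of 2-methylphenyl on a carbonyl carbon.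

Along with those two steps, the exchange of bromo for chloro also bears on this change, with a 1.5-fold lower number from compound 1 to compound 2 (0.19 log units; within the scatter). All three measured steps stay within the scatter, so the aryl changes tried so far have not separated these compounds in this assay. Among the measured compounds shown here, none of the measured compounds carries a 4-methoxyphenyl group, so the expectation rests on three compounds only. No step beyond the scatter is expected, and the expected step is a 1.3-fold lower number from compound 3 to compound 4 (0.10 log units; within the scatter). The estimate for compound 4 is 4.8 ug/mL, with an expected range of 2.2 ug/mL to 10 ug/mL.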

Compound 4, half-maximal inhibitory concentration: 5.8 ug/mL
Estimate against measurement, compound 4: 1.2-fold (0.08 log units) below; low and high end bracket the measured number.
By their numbers in this assay, from the lowest: compounds 2, 1, 4 and 3 (each within the scatter of the next).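

In this assay, among the compounds shown here, 4-methoxyphenyl is the first group on this carbonyl carbon to bring in an oxygen and a hydrogen-bond acceptor, yet its exchange for 2-methylphenyl leaves the number within the scatter (a 1.1-fold lower number from compound 3 to compound 4 (0.02 log units; within the scatter)). The comparisons with the halogen-bearing aryl groups also stay within the scatter (a 1.8-fold higher number from compound 2 to compound 4 (0.24 log units; within the scatter); a 1.1-fold higher number from compound 1 to compound 4 (0.06 log units; within the scatter)), so 2-methylphenyl, 3-chlorophenyl, 3-bromophenyl and 4-methoxyphenyl are not separated at this position. No measured evidence accounts for this lack of separation.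

As far as these compounds go, whether any group on this carbonyl carbon can move the number beyond the scatter remains open, and a phenyl ring carrying an amine or a carboxylic acid, or a saturated cyclohexyl ring in place of the aryl group, would test this. Also open, from the compounds shown here alone, is whether the lack of separation holds for changes elsewhere on the shared core.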